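The source may hold more compounds than are shown below. What is called first, only, known or untested is meant among the compounds shown, and "the series" means these compounds.

Measured in a functional assay on CCRF-CEM cells (Homo sapiens) for antiproliferative activity; on this read-out higher numbers stand for weaker inhibition and lower numbers for stronger inhibition:
- compound 1 `COc1cc(C(=O)c2sc(-c3ccccc3)cc2N)cc(OC)c1OC`: 4.5 nM
- compound 2 `COc1cc(C(=O)c2sc(-c3ccccc3Cl)cc2N)cc(OC)c1OC`: 16 nM

Compound 2 has the higher number of the two. Among the measured compounds shown here, the only measured step, a 3.6-fold higher number from compound 1 to compound 2 (0.55 log units; beyond the scatter), comes with chloro in place of hydrogen on an aromatic carbon. Compound 3 `COc1ccc(-c2cc(N)c(C(=O)c3cc(OC)c(OC)c(OC)c3)s2)cc1` has not yet been measured in this assay. Its change is 4-methoxyphenyl in place of 2-chlorophenyl on an aromatic carbon. For the measured compounds named here, the chloro step bears on this only in part, since the chlorine leaves but no measured compound carries 4-methoxyphenyl. A modest move towards a lower number is therefore expected, with a 2.3-fold lower number from compound 2 to compound 3 (0.36 log units; beyond the scatter) as the estimated step. Compound 3 is expected at 7 nM, within an estimated range of 2 nM to 30 nM.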

Compound 3, half-maximal inhibitory concentration: 19 nM
The estimate for compound 3 lay 2.7-fold (0.43 log units) below the measured number, within the range that was stated.
By their numbers in this assay, from the lowest: compound 1; then compounds 2 and 3 (each within the scatter of the next).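

In this assay there is a 1.2-fold higher number from compound 2 to compound 3 (0.07 log units; within the scatter) when 4-methoxyphenyl replaces 2-chlorophenyl, so on this carbon next to the ring sulfur the two groups are not told apart. Methoxy in place of hydrogen gives a 4.2-fold higher number from compound 1 to compound 3 (0.63 log units; beyond the scatter) and, with chloro, makes a second substituent on the phenyl ring that goes with a higher number than in compound 1. Nothing available explains these numbers.

On these data alone, how 4-chlorophenyl or 2-methoxyphenyl would read here stays open, so the effect of the group and that of its place on the phenyl ring remain unseparated.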